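The source may hold more compounds than are shown below. What is called first, only, known or untested is meant among the compounds shown, and "the series" means these compounds.

Measured so far:
compound 1 `CN1CCC(COC(c2ccccc2)c2ccccc2)CC1`: > 20000 nM (a limit)
compound 2 `COc1ccccc1CCCN1CCC(COC(c2ccccc2)c2ccccc2)CC1`: 2400 nM
compound 3 `CCCCCN1CCC(COC(c2ccccc2)c2ccccc2)CC1`: 10800 nM

In a functional assay on cells (T-cell line, Homo sapiens) for inhibition (on this read-out higher numbers stand for weaker inhibition and lower numbers for stronger inhibition), compound 3 gives 10800 nM, the higher of the two actual numbers in the series. Its nearest neighbour is compound 2 at 2400 nM. Compound 1 stands only at a limit, > 20000 nM.

Compound 4 `CCCCCCCCCCN1CCC(COC(c2ccccc2)c2ccccc2)CC1` has pentyl in place of hydrogen on a saturated chain carbon, five bonds along the chain from an amine nitrogen in a ring.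

For the measured compounds named here, the closest precedent is the addition of butyl, an at least 1.8-fold lower number from compound 1 to compound 3 (0.26 log units; that floor lies within the scatter), although that floor lies within the scatter. Two further steps show that the substituent on this chain can move the number: an at least 8.3-fold lower number from compound 1 to compound 2 (0.92 log units; beyond the scatter) and a 4.5-fold higher number from compound 2 to compound 3 (0.65 log units; beyond the scatter). Both are beyond the scatter, but neither is a plain chain extension, so they bear on compound 4 only loosely. A modest move towards a lower number is therefore expected, and no change beyond the scatter remains possible.

The expected step is a 3.1-fold lower number from compound 3 to compound 4 (0.49 log units; beyond the scatter). For compound 4 the estimated value is 3500 nM, with an expected range of 1000 nM to 14000 nM.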

Compound 4, half-maximal inhibitory concentration: 2600 nM
Beside the measured number, compound 4's estimate is 1.3-fold (0.13 log units) above it; measured number inside the range.
By their numbers in this assay, from the lowest: compounds 2 and 4 (each within the scatter of the next); then compound 3. At a limit, above all of these: compound 1.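

In this assay, pentyl in place of hydrogen on a saturated chain carbon, five bonds along the chain from an amine nitrogen in a ring, gives a 4.2-fold lower number from compound 3 to compound 4 (0.62 log units; beyond the scatter), so plain chain extension alone now moves the number beyond the scatter. Heptyl in place of 2-methoxyphenyl gives a 1.1-fold higher number from compound 2 to compound 4 (0.03 log units; within the scatter), which shows that a chain without an aryl group can stand level with the 2-methoxyphenyl compound within the scatter. Nonyl in place of hydrogen gives an at least 7.6-fold lower number from compound 1 to compound 4 (0.88 log units; beyond the scatter), but the size of this step is only a floor, as it starts from a limit: the limit of > 20000 nM in this assay, at which 1 of the 4 values shown sits.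

As far as these compounds go, whether a chain longer than that of compound 4 lowers the number further or raises it again remains open. Also open, from the compounds shown here alone, is whether a hydroxyl or an amine on this chain would keep the number of compound 4.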